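Methoxy-to-chloro swaps on the benzyl group of an M5 series

The source may hold more compounds than are shown below. What is called first, only, known or untested is meant among the compounds shown, and "the series" means these compounds.

Measured so far:
compound 1 `CCN(Cc1cccc(Cl)c1)C(=O)C1CCN(S(=O)(=O)c2ccc3cn[nH]c3c2)CC1`: 77%
compound 2 `CCN(Cc1cccc(OC)c1)C(=O)C1CCN(S(=O)(=O)c2ccc3cn[nH]c3c2)CC1`: 85%
compound 3 `CCN(Cc1ccccc1OC)C(=O)C1CCN(S(=O)(=O)c2ccc3cn[nH]c3c2)CC1`: 92%

The three measured compounds share one core and differ only in the benzyl group on the saturated chain carbon bound to the amide-type nitrogen. In a functional assay on CHO cells for positive allosteric modulation of muscarinic acetylcholine receptor M5 (Homo sapiens), read by calcium flux (a lower number here means a smaller maximal response, a higher number a larger maximal response), compound 1 gives 77%, compound 2 gives 85% and compound 3 gives 92%. Within the data shown here, compound 3 stands highest of the three, though only the step of a number 15 percentage points higher from compound 1 to compound 3 (beyond the scatter) lies beyond the scatter; the step of a number 7 percentage points higher from compound 2 to compound 3 (within the scatter) does not. Compound 2 and compound 3 have the same atoms joined differently: 2-methoxyphenyl in place of 3-methoxyphenyl on a saturated chain carbon bound to an amide-type nitrogen.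

Compound 4 `CCN(Cc1ccccc1Cl)C(=O)C1CCN(S(=O)(=O)c2ccc3cn[nH]c3c2)CC1` is not yet measured. Against compound 3 the difference is chloro in place of methoxy on an aromatic carbon. The same change is already made once, (chloro in place of methoxy on an aromatic carbon), and there it gave a number 8 percentage points lower from compound 2 to compound 1 (within the scatter). The places are not the same word for word: meta to a large group in the measured pair, ortho to a large group here, so this is the same kind of change, not the same. Beside the measured step of a number 8 percentage points lower from compound 2 to compound 1 (within the scatter), the expected step is a number 8 percentage points lower from compound 3 to compound 4 (within the scatter). Compound 4 is estimated at 84%, with a range from 74% to 94%.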

Compound 4, largest response reached (reported as percent of maximum), in percent of the reference or control that the assay uses: 93%
The estimate for compound 4 lay 9 percentage points below the measured number; the measured number falls inside the stated range.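

In this assay, chloro in place of methoxy on an aromatic carbon gives a number 1 percentage points higher from compound 3 to compound 4 (within the scatter), and the two instances of this swap do not differ: the same change on two cores in this assay, a number 8 percentage points lower (within the scatter) from compound 2 to compound 1 and a number 1 percentage points higher (within the scatter) from compound 3 to compound 4, 9 percentage points apart, within the scatter of two such steps. Moving the substituent also gives a number 16 percentage points higher from compound 1 to compound 4 (beyond the scatter) for the chloro pair, whereas a number 8 percentage points higher from compound 2 to compound 4 (within the scatter) is a step that mixes both changes and stays within the scatter. Two pairs with small steps show that the swap carried across these two cores without a step beyond the scatter, but they do not show that it would carry to other cores or to other read-outs.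

Going by these compounds, how an amine or a carboxylic acid on that aromatic carbon would read remains open.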